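The compounds below may be only part of what the source reports. "The series", "measured", "known", "first", "only" and "open" are said of these compounds alone.

In a functional assay on HCT-116 cells (Homo sapiens) for inhibition, read by MTT assay, with a stated time of 72 h (on this read-out lower numbers stand for stronger inhibition and higher numbers for weaker inhibition), compound 1 (`CC(C)CCN(CCCCCC(=O)NO)c1ncc(C(=O)NCCCn2ccnc2)s1`) gives 85000 nM and compound 2 (`O=C(/C=C/c1ccc(CN(Cc2ccc(F)cc2)c2ncc(C(=O)NCCCn3ccnc3)s2)cc1)NO`) gives 83000 nM, so compound 2 stands level with compound 1, within the usual scatter. Compound 3 (`O=C(CCCCCN(Cc1ccc(F)cc1)c1ncc(C(=O)NCCCn2ccnc2)s1)NO`) has 4-(hydroxycarbamoyl)butyl in place of 4-(2-(hydroxycarbamoyl)ethenyl)phenyl on a saturated chain carbon bound to a nitrogen on an aromatic ring. Compound 1 also has a saturated chain ending in hydroxycarbamoyl and reads 85000 nM, so no change beyond the scatter is expected in this assay. The expected 1.4-fold lower number from compound 2 to compound 3 (0.14 log units; within the scatter) is small. The estimate for compound 3 is 60000 nM, with a range of 15000 nM to 150000 nM.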

Compound 3, half-maximal inhibitory concentration: 19000 nM
Compound 3: the middle estimate sits 3.2-fold (0.50 log units) above what was measured; measured number inside the range.
By their numbers in this assay, from the lowest: compound 3; then compounds 2 and 1 (each within the scatter of the next).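

In this assay, putting 4-(hydroxycarbamoyl)butyl in place of 4-(2-(hydroxycarbamoyl)ethenyl)phenyl gives a 4.4-fold lower number from compound 2 to compound 3 (0.64 log units; beyond the scatter) and so shows that this swap on the saturated chain carbon changes inhibition beyond the scatter. The other position also counts: 4-fluorophenyl in place of isobutyl gives a 4.5-fold lower number from compound 1 to compound 3 (0.65 log units; beyond the scatter) with the hydroxycarbamoyl chain held fixed. Nothing available explains either step. Still open, on these data alone, is whether a longer chain ending in hydroxycarbamoyl would lower the number further, and whether a carboxylic acid could stand in for the hydroxycarbamoyl group.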